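Extending the Selenium Chain on Compound 1

This account rests on a few compounds, and the source may have more. Where it says the series, first, only, none or still open, it means among the compounds named here.

Measured compounds:
- compound 1 `C[Se]c1nc(N)c2ccccc2n1`: > 100000 nM
- compound 2 `CSc1nc(NCCCCc2ccccc2)c2ccccc2n1`: 64000 nM
- compound 3 `C[Se]c1nc([Se]C)c2ccccc2n1`: 50700 nM

The three measured compounds share one core and were tested in a functional assay on MCF7 cells (Homo sapiens) for cytotoxicity, read by MTT assay, with a stated time of 72 h; a higher number here means a weaker inhibitor of growth, a lower number a stronger inhibitor of growth. For compound 1 the result > 100000 nM is a limit of the assay, not a number. Compound 3 gives 50700 nM, and the change from compound 1 to compound 3 is an at least 1.9-fold lower number from compound 1 to compound 3 (0.29 log units; that floor lies within the scatter), so it cannot be read as a real gain. Compound 2, which is not a single-point neighbour of the others, gives 64000 nM.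

Compound 4 `CCCCC[Se]c1nc(N)c2ccccc2n1` differs from compound 1 by butyl in place of hydrogen on a saturated chain carbon bound to a selenium atom. Within the data shown here, no measured step touches this chain directly; the only measured step from compound 1, an at least 1.9-fold lower number from compound 1 to compound 3 (0.29 log units; that floor lies within the scatter), sits within the scatter and starts from a limit (the limit of > 100000 nM in this assay, at which 1 of the 3 values shown sits). The numbers therefore give little reason to expect a large change in this assay in either direction, though a modest move to a lower number would not be surprising.

Compound 4 is expected to give about 80000 nM, within 30000 nM to 200000 nM. The expected step from compound 1 is an at least 1.2-fold lower number from compound 1 to compound 4 (0.09 log units; that floor lies within the scatter).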

Compound 4, concentration for total growth inhibition: 59500 nM
The estimate for compound 4 lay 1.3-fold (0.13 log units) above the measured number, within the range that was stated.
By their numbers in this assay, from the lowest: compounds 3, 4 and 2 (each within the scatter of the next). At a limit, above all of these: compound 1.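

Compound 4 carries the change on the chain itself, methyl to pentyl on the selenium atom, and with it this assay gives a number rather than a limit. Compound 1 remains a limit and not a number: the limit of > 100000 nM in this assay, at which 1 of the 4 values shown sits. From the compounds shown here alone, the step is read as an at least 1.6-fold lower number from compound 1 to compound 4 (0.22 log units; that floor lies within the scatter), so the pentyl chain leaves growth inhibition measurable, but its true size is unknown and no real gain can be claimed.

Going by these compounds, whether a shorter chain such as ethyl, or a longer one such as octyl, would move the number beyond the scatter stays open. On these data alone, it is also open what a chain ending in an amine or a carboxylic acid would do on the core of compound 1.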